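The compounds below may be only part of what the source reports. "The series", "measured", "known", "first", "only" and "open" are said of these compounds alone.

In a functional assay on A549 cells (Homo sapiens) for antiproliferative activity, read by MTT assay, with a stated time of 48 h (a higher number here means a weaker inhibitor, a lower number a stronger inhibitor), compound 1 (`Cc1ccc(C(=O)/C=C/c2cccc(Br)c2Oc2c([N+](=O)[O-])cc(C(F)(F)F)cc2[N+](=O)[O-])cc1`) reads 6.85 ug/mL and compound 2 (`COc1ccc(C(=O)/C=C/c2cccc(Br)c2Oc2c([N+](=O)[O-])cc(C(F)(F)F)cc2[N+](=O)[O-])cc1`) reads 12.7 ug/mL while compound 3 (`O=C(/C=C/c1cc(Br)cc(Br)c1Oc1c([N+](=O)[O-])cc(C(F)(F)F)cc1[N+](=O)[O-])c1ccc(Cl)cc1`) reads 19.4 ug/mL on the same scale. Compound 3 cannot be told apart from compound 2 on these numbers, but its number is higher than that of compound 1 by more than the usual scatter. Compound 4 (`O=C(/C=C/c1cccc(Br)c1Oc1c([N+](=O)[O-])cc(C(F)(F)F)cc1[N+](=O)[O-])c1ccc(Cl)cc1`) differs from compound 3 in a single place: hydrogen in place of bromo on an aromatic carbon. This leaves compound 4 with one bromo group, like compound 1 and compound 2.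

For the measured compounds named here, no measured step tests this change directly. Going by the values given here, the only step available is a 1.9-fold higher number from compound 1 to compound 2 (0.27 log units; within the scatter) for methoxy in place of methyl on an aromatic carbon, which is a different change and gives only a rough idea of how far close relatives lie apart. Since compound 1 at 6.85 ug/mL has a lower number than compound 3, a small move toward a lower number in this assay is expected (a 1.8-fold lower number from compound 3 to compound 4 (0.25 log units; within the scatter)) and it probably stays within the scatter. The estimated value for compound 4 is 11 ug/mL with an expected range from 5 ug/mL to 24 ug/mL in this test.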

Compound 4, half-maximal inhibitory concentration: 16.5 ug/mL
Compound 4: the middle estimate sits 1.5-fold (0.18 log units) below what was measured, within the range that was stated.
By their numbers in this assay, from the lowest: compounds 1, 2, 4 and 3 (each within the scatter of the next, the first and the last beyond it).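

In this assay, swapping this bromo group, meta to a 2-((4-chlorophenyl)carbonyl)ethenyl group, for hydrogen gives a 1.2-fold lower number from compound 3 to compound 4 (0.07 log units; within the scatter) and so produces no readable change, which means the second bromo group makes no visible difference in this pair. For the compounds shown here, with one bromo group kept, chloro in place of methoxy gives a 1.3-fold higher number from compound 2 to compound 4 (0.11 log units; within the scatter) and is also unreadable, whereas chloro in place of methyl gives a 2.4-fold higher number from compound 1 to compound 4 (0.38 log units; beyond the scatter) and is the only one of these three steps to clear the scatter, though modestly. No measurement offers a reason for any of these steps.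

The compounds shown leave open how an amine or a carboxylic acid would read at this position. They also leave open whether removing this bromo group would stay as unreadable with methyl or methoxy in place of the chloro.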